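The source may hold more compounds than are shown below. What is called first, only, known or untested is meant among the compounds shown, and "the series" means these compounds.

Compound 3, `O=c1c2ccccc2[se]n1-c1nc(SCc2ccc(Cl)cc2)n[nH]1`, gives 39500 nM in an ADME assay on L929 cells (Mus musculus) for antiproliferative activity, read by CCK-8 assay, with a stated time of 48 h (on this read-out higher numbers stand for weaker inhibition and lower numbers for stronger inhibition), which is the highest of the two numbers reported, with compound 1, `CC(C)CSc1n[nH]c(-n2[se]c3ccccc3c2=O)n1`, nearest at 33400 nM; the two lie within the scatter of each other, as the step of a 1.2-fold higher number from compound 1 to compound 3 (0.07 log units; within the scatter) shows. Compound 2, `Cc1ccc(CSc2n[nH]c(-n3[se]c4ccccc4c3=O)n2)cc1`, is reported in this assay only as a limit, > 50000 nM.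

Compound 4, `Cc1ccccc1CSc1n[nH]c(-n2[se]c3ccccc3c2=O)n1`, differs from compound 3 in one place: 2-methylphenyl in place of 4-chlorophenyl on a saturated chain carbon bound to a sulfur.

For the measured compounds named here, two measured steps bear on this change. The step of an at least 1.4-fold higher number from compound 1 to compound 2 (0.17 log units; that floor lies within the scatter) and the step of a 1.2-fold higher number from compound 1 to compound 3 (0.07 log units; within the scatter) show that replacing isopropyl by either aryl group moved the number little, and the step of an at least 1.2-fold lower number from compound 2 to compound 3 (0.10 log units; that floor lies within the scatter) shows that chloro in place of methyl on the aromatic carbon gave at most a small lowering, its floor inside the scatter. None of these steps reaches beyond the scatter, so no step beyond the scatter is expected from compound 3 to compound 4 either, with a slight lean toward a higher number because compound 2 already sits at the limit of > 50000 nM in this assay, at which 1 of the 3 values shown sits.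

Compound 4 is therefore expected to give about 45000 nM in this assay, between 22000 nM and 90000 nM, meaning an expected step of a 1.1-fold higher number from compound 3 to compound 4 (0.06 log units; within the scatter).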

Compound 4, half-maximal inhibitory concentration: 15600 nM
Compound 4: the middle estimate sits 2.9-fold (0.46 log units) above what was measured; the measured number lies below the stated range.
By their numbers in this assay, from the lowest: compound 4; then compounds 1 and 3 (each within the scatter of the next). At a limit, above all of these: compound 2.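

In this assay, for the compounds shown here, 2-methylphenyl is the first group on this saturated chain carbon bound to a sulfur to move the number clearly beyond the scatter, giving a 2.5-fold lower number from compound 3 to compound 4 (0.40 log units; beyond the scatter) and a 2.1-fold lower number from compound 1 to compound 4 (0.33 log units; beyond the scatter), whereas the earlier steps, or their floors, stayed within it. An aryl group as such is therefore not what counts, for 4-chlorophenyl in compound 3 left the number within the scatter of compound 1, while the change from 4-methylphenyl to 2-methylphenyl gives an at least 3.2-fold lower number from compound 2 to compound 4 (0.50 log units; beyond the scatter). That last step is only a floor, as compound 2 is reported as a limit and not as a number: the limit of > 50000 nM in this assay, at which 1 of the 4 values shown sits.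

The compounds shown leave open whether the lowering belongs to the methyl group in particular or would also appear with 2-chlorophenyl, 2-methoxyphenyl or an unsubstituted phenyl group on the same carbon. They also leave open whether a longer chain between the sulfur and the 2-methylphenyl group would keep it, and the numbers themselves give no cause for the change.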